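This account rests on a few compounds, and the source may have more. Where it says the series, first, only, none or still open, it means among the compounds named here.

Of the compounds shown here, three have so far been tested in a functional assay on HT-29 cells (Homo sapiens) for inhibition, read by MTT assay, with a stated time of 72 h; on this read-out lower numbers stand for stronger inhibition and higher numbers for weaker inhibition. Compound 2 `CN(C)CCn1c(=O)c(=Cc2ccc(F)c(F)c2)s/c1=C1\C(=O)Nc2cc(F)ccc21` gives 12100 nM, the highest number of the three and therefore the weakest inhibition shown. The compound nearest to it is compound 1 `COc1cc(C=c2s/c(=C3\C(=O)Nc4ccc(F)cc43)n(CCN(C)C)c2=O)cc(OC)c1OC`, which in this assay gives 2530 nM; compound 1 differs from compound 2 in more than one place, so only its two values can be set side by side. For the measured compounds named here, compound 3 `CCN(CC)CCCn1c(=O)c(=Cc2ccc(F)c(F)c2)s/c1=C1\C(=O)Nc2cc(F)ccc21` gives 28 nM in this assay, and the single measured step, a 430-fold lower number from compound 2 to compound 3 (2.64 log units; beyond the scatter), alters only the amine on the side chain.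

Compound 4 `CN(C)CCn1c(=O)c(=Cc2ccc(C=O)c(C=O)c2)s/c1=C1\C(=O)Nc2cc(F)ccc21` remains unmeasured. It differs from compound 2 by 3,4-diformylphenyl in place of 3,4-difluorophenyl on a double-bonded chain carbon bound to an aromatic carbon. Going by the values given here, no measured step touches this part of the molecule: the step from compound 2 to compound 3 sits on the chain, and compound 1 carries several changes at once. Compound 4 is therefore expected to stay near compound 2, with the expected step of a 1.2-fold lower number from compound 2 to compound 4 (0.08 log units; within the scatter) not reaching beyond the scatter. The estimate for compound 4 in this assay is 10000 nM, within a range from 2500 nM to 40000 nM.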

Compound 4, half-maximal inhibitory concentration: 1360 nM
Compound 4: the middle estimate sits 7.4-fold (0.87 log units) above what was measured; the measured number lies below the stated range.
By their numbers in this assay, from the lowest: compound 3; then compounds 4 and 1 (each within the scatter of the next); then compound 2.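

In this assay, replacing 3,4-difluorophenyl with 3,4-diformylphenyl on a double-bonded chain carbon bound to an aromatic carbon gives an 8.9-fold lower number from compound 2 to compound 4 (0.95 log units; beyond the scatter). For the compounds shown here, this is the first single change measured at this position, and it shows that the number responds to the aromatic group here as well as to the amine on the side chain. The entering group has hydrogen-bond acceptors and the leaving group has none, but no measurement here links the step to that difference or to any other property of the formyl groups.

On these data alone, it remains open whether a phenyl ring bearing nitrile or carboxylic acid groups in place of the formyl groups would give a similar number. As far as these compounds go, it is also open whether 3,4-diformylphenyl would shift the number in the same direction when paired with the side chain of compound 3.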